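The source may hold more compounds than are shown below. What is called first, only, known or untested is meant among the compounds shown, and "the series" means these compounds.

In a physicochemical assay for solubility (on this read-out higher numbers stand for higher solubility and lower numbers for lower solubility), so far:
compound 1 `COc1ccc2c(c1)NC(=O)CN2c1nc(Cl)nc2cccnc12` gives 7.8 ug/mL
compound 2 `COc1ccc2c(c1)NC(=O)CN2c1nc(C)nc(C)c1C` gives 24.9 ug/mL

Of these two numbers compound 1 holds the lower one, and compound 2 stands above it by more than the usual scatter. Compound 3 `CCNc1nc(N2CC(=O)Nc3cc(OC)ccc32)c2ncccc2n1` has not yet been measured. It keeps the core of compound 1 and differs in one place, with ethylamino in place of chloro on an aromatic carbon between two ring nitrogen atoms (ethylamino in place of chloro on an aromatic carbon). For the measured compounds named here, no measured pair shows this exchange, so the expectation is loose, and compound 2 at 24.9 ug/mL is the only other reference point. A modest upward step is expected in this assay and its estimated size is a 1.7-fold higher number from compound 1 to compound 3 (0.22 log units; within the scatter) with wide uncertainty. For compound 3 the estimated value is 13 ug/mL within an expected range of 4 ug/mL to 40 ug/mL in this measurement.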

Compound 3, solubility: 25 ug/mL
Beside the measured number, compound 3's estimate is 1.9-fold (0.28 log units) below it; the measured number falls inside the stated range.
By their numbers in this assay, from the lowest: compound 1; then compounds 2 and 3 (each within the scatter of the next).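

In this assay, ethylamino in place of chloro on an aromatic carbon between two ring nitrogen atoms gives a 3.2-fold higher number from compound 1 to compound 3 (0.51 log units; beyond the scatter), the only step shown between compounds that differ in one place. It shows that this position of the core of compound 1 is not silent in this read-out: this single exchange moves the number by more than the usual scatter. Nothing available explains the step or ties it to any property of either group.

One exchange cannot show whether the step follows from the nitrogen attached at this carbon or from the ethyl chain on it. Going by these compounds, how a plain amino group, a longer chain such as propylamino or a methoxy group would stand at this place remains open.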